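The compounds below may be only part of what the source reports. "The series", "measured", "known", "first", "only" and "open" are said of these compounds alone.

Two compounds share one core and differ only in the aromatic group attached to it. Compound 1 `CCCS(=O)(=O)Nc1ccc(F)c(C(=O)c2n[nH]c3ncc(-c4ccc(C)cc4)cc23)c1F` carries a 4-methylphenyl there, and in an assay for binding affinity to dual specificity mitogen-activated protein kinase kinase 4 (Homo sapiens), read by KINOMEscan, tested at 100 nM (a lower number here means a stronger effect, a higher number a weaker effect of the compound at the concentration tested), compound 1 gives 5.4%. Compound 2 `CCCS(=O)(=O)Nc1ccc(F)c(C(=O)c2n[nH]c3ncc(-c4ccc(OC)cc4Cl)cc23)c1F` carries a 2-chloro-4-methoxyphenyl instead, and in this assay compound 2 gives 5.3%. On the numbers shown, compound 2 sits alongside compound 1, since the step of a number 0.1 percentage points lower from compound 1 to compound 2 (within the scatter) lies within the scatter and the two readings cannot be told apart. Compound 3 `CCCS(=O)(=O)Nc1ccc(F)c(C(=O)c2n[nH]c3ncc(-c4ccc(C(F)(F)F)cc4)cc23)c1F` has not yet been measured. It differs from compound 2 in one place: 4-(trifluoromethyl)phenyl in place of 2-chloro-4-methoxyphenyl on an aromatic carbon. Among the compounds with values here, the only measured step that bears on this change is the one that swapped the same aromatic group, a number 0.1 percentage points lower from compound 1 to compound 2 (within the scatter), and that step stayed within the scatter. Within the data shown here, with one such step as the sole guide, there is no ground to expect a change beyond the scatter in this assay. The expected step of a number 0.7 percentage points higher from compound 2 to compound 3 (within the scatter) is therefore close to nothing. For compound 3 the estimate in this assay is 6%, with a range from 1% to 25%.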

Compound 3, a percentage reported as activity, at one concentration (the size of the read-out at that concentration, not a potency): 29%
Compound 3: the middle estimate sits 23 percentage points below what was measured; the measured number lies above the stated range.
By their numbers in this assay, from the lowest: compounds 2 and 1 (each within the scatter of the next); then compound 3.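

The aromatic group on the shared core is not a place where any swap leaves this assay unchanged: the two earlier groups read alike, but 4-(trifluoromethyl)phenyl in place of 2-chloro-4-methoxyphenyl gives a number 23.7 percentage points higher from compound 2 to compound 3 (beyond the scatter), and a higher number here means a weaker effect. The tightest comparison is a number 23.6 percentage points higher from compound 1 to compound 3 (beyond the scatter), since only trifluoromethyl takes the place of methyl and the rest of the phenyl group stays the same, so one small substituent is enough to shift the reading beyond the scatter. Nothing available explains why this substitution weakens the effect.

The compounds shown leave open whether the loss is specific to trifluoromethyl or would also appear with other groups in that same place on the phenyl ring, such as a single chlorine, a nitrile or an ethyl chain. They also leave open whether adding a 2-chloro group to the 4-(trifluoromethyl)phenyl ring, as in the group of compound 2, would bring the reading back down.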